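The compounds below may be only part of what the source reports. "The series", "measured", "known", "first", "only" and "open" are said of these compounds alone.

Compound 1 `COc1cccc(/C(=C\c2cn(C(C)=O)c3ccc(OCc4ccccc4)cc23)C(=O)O)c1`: 1080 nM
Compound 2 `CC(=O)n1cc(/C=C(/C(=O)O)c2ccc(Cl)cc2)c2cc(OCc3ccccc3)ccc21`: 1130 nM

Among the measured compounds shown here, in a functional assay on DU-145 cells (Homo sapiens) for cytotoxicity, read by MTT assay, with a stated time of 72 h (on this read-out lower numbers stand for stronger inhibition and higher numbers for weaker inhibition), compound 2 gives 1130 nM, and the only other compound, compound 1, gives 1080 nM; the gap, a 1.0-fold higher number from compound 1 to compound 2 (0.02 log units; within the scatter), lies within the scatter, so the two count as equal. Compound 3 `COc1cc(OC)cc(/C(=C\c2cn(C(C)=O)c3ccc(OCc4ccccc4)cc23)C(=O)O)c1` differs from compound 2 by 3,5-dimethoxyphenyl in place of 4-chlorophenyl on a double-bonded chain carbon bound to a carbonyl carbon and a double-bonded chain carbon. For the measured compounds named here, the one measured step, a 1.0-fold higher number from compound 1 to compound 2 (0.02 log units; within the scatter), also swaps the aryl group at this position and changed nothing beyond the scatter, so compound 3 is expected to show no step beyond the scatter, a 1.0-fold lower number from compound 2 to compound 3 (0.01 log units; within the scatter). Compound 3 is therefore estimated at 1100 nM, ranging from 450 nM to 2700 nM.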

Compound 3, half-maximal inhibitory concentration: 880 nM
For compound 3 the middle estimate is 1.3-fold (0.10 log units) above the measured one; measured number inside the range.
By their numbers in this assay, from the lowest: compounds 3, 1 and 2 (each within the scatter of the next).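

In this assay, a third aryl group on this double-bonded chain carbon again leaves the number within the scatter, with a 1.3-fold lower number from compound 2 to compound 3 (0.11 log units; within the scatter). Methoxy in place of hydrogen on an aromatic carbon of the aryl ring also changes nothing beyond the scatter, with a 1.2-fold lower number from compound 1 to compound 3 (0.09 log units; within the scatter). No evidence is available to explain this flat result.

All three groups at this position are substituted phenyl rings. Going by these compounds, whether an amine on that ring, or a longer chain in place of the ring, would shift the number remains open.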